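This account rests on a few compounds, and the source may have more. Where it says the series, first, only, none or still open, it means among the compounds named here.

Series notes. Compound 1 `O=C1COc2ccc(-c3cccc(NS(=O)(=O)c4ccc(F)cc4)c3)cc2N1c1ccccc1` has been read in a functional assay on HCT-116 cells (Homo sapiens) for antiproliferative activity, read by MTT assay, with a stated time of 72 h; a higher number here means a weaker inhibitor, a lower number a stronger inhibitor. In this assay compound 1 gives > 40000 nM, which is a limit of the assay and not a number. Within the data shown here, compound 2 `COc1ncc(-c2ccc3c(c2)N(c2ccc(F)cc2)C(=O)CO3)cc1NS(=O)(=O)c1ccc(F)cc1` is the only other compound read, and in this assay compound 2 gives > 40000 nM, again a limit only. Among the measured compounds shown here, compound 1 therefore stands at the limit of > 40000 nM in this assay, at which 2 of the 2 values shown sit, and no measured step between two compounds exists so far.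

Compound 3 `COc1ccc(N2C(=O)COc3ccc(-c4cccc(NS(=O)(=O)c5ccc(F)cc5)c4)cc32)cc1` has not yet been measured in this assay. It differs from compound 1 by methoxy in place of hydrogen on an aromatic carbon; the change sits on an aromatic carbon of a six-membered aromatic ring of carbon only, para to a large group, and cut one bond further out reads phenyl to 4-methoxyphenyl. For the measured compounds named here, with both known values sitting at the limit, no step in this assay beyond the usual scatter is expected in either direction, and a limit is again the most likely report. The estimate for compound 3 in this assay is 40000 nM, expected to lie between 15000 nM and 100000 nM. The expected step is a number no higher from compound 1 to compound 3 (the limit leaves the size open), nothing beyond the scatter.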

Compound 3, half-maximal inhibitory concentration: 28300 nM
For compound 3 the middle estimate is 1.4-fold (0.15 log units) above the measured one; low and high end bracket the measured number.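

In this assay, methoxy in place of hydrogen on an aromatic carbon, para to a large group, gives an at least 1.4-fold lower number from compound 1 to compound 3 (0.15 log units; that floor lies within the scatter). Among these compounds, compound 3 gives 28300 nM, the only reading that is a number, so the change from phenyl to 4-methoxyphenyl at this position is the one place where a value can be read. The other readings remain at the limit: the limit of > 40000 nM in this assay, at which 2 of the 3 values shown sit.

Going by these compounds, the true size of the step stays open, as the reading for compound 1 is a limit of the assay and not a number. Also open, on these data alone, is whether an amine, a carboxylic acid or a longer chain such as ethoxy in the same place would give a step beyond the scatter.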